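The compounds below may be only part of what the source reports. "The series", "measured", "known", "first", "only" and "open" are said of these compounds alone.

Compound 1 `Cc1cccc(NC(=O)N[C@@H]2C[C@H](c3ccccc3)C[C@H](c3ccc(F)cc3)N(CC(=O)NC(C)(C)C)C2=O)c1` gives 2.8 nM in an assay on isolated protein for inhibition of Cholecystokinin receptor type A (Cavia porcellus); on this read-out lower numbers stand for stronger inhibition and higher numbers for weaker inhibition. Compound 2 `Cc1ccc([C@H]2C[C@@H](c3ccccc3)C[C@@H](NC(=O)Nc3cccc(C)c3)C(=O)N2CC(=O)NC(C)(C)C)cc1` gives 970 nM, and the step of a 350-fold higher number from compound 1 to compound 2 (2.54 log units; beyond the scatter) shows how much one aryl change can move this read-out. Compound 3 `Cc1cccc(NC(=O)N[C@@H]2C[C@H](c3ccc(F)cc3)C[C@H](c3ccccc3)N(CC(=O)NC(C)(C)C)C2=O)c1` gives 700 nM: second highest of the three numbers, within the scatter of compound 2 and far from compound 1. Compound 4 `CCc1ccccc1[C@@H]1C[C@H](c2ccccc2)N(CC(=O)NC(C)(C)C)C(=O)[C@H](NC(=O)Nc2cccc(C)c2)C1` carries the change (2-ethylphenyl in place of 4-fluorophenyl on a saturated ring carbon), that is, 2-ethylphenyl in place of 4-fluorophenyl on a saturated ring carbon. No measured step tests this exchange; the only step shown concerns a different ring carbon, so its size is a warning rather than a guide. Compound 4 is therefore expected to stay near compound 3, with the step of a 1.4-fold lower number from compound 3 to compound 4 (0.15 log units; within the scatter) estimated as small, giving 500 nM within 100 nM to 3000 nM.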

Compound 4, half-maximal inhibitory concentration: 810 nM
For compound 4 the middle estimate is 1.6-fold (0.21 log units) below the measured one, and the stated range covers the measured number.
By their numbers in this assay, from the lowest: compound 1; then compounds 3, 4 and 2 (each within the scatter of the next).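

In this assay, the exchange at this saturated ring carbon gives a 1.2-fold higher number from compound 3 to compound 4 (0.06 log units; within the scatter) as its step, so this read-out does not separate 2-ethylphenyl from 4-fluorophenyl here. Going by these compounds alone, this is the only measured exchange at this position, and it holds for a single pair with the same phenyl group and the same ((3-methylphenyl)carbamoyl)amino group. Nothing available explains why the two aryl groups read alike. Open, from the compounds shown here alone, is whether a carboxylic acid or an amine on the aromatic ring at this position would move the number, and whether a longer chain in place of the ethyl group would do so.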